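Replacing cyanobenzyl with pyridylmethyl: expected cytotoxicity

The compounds below may be only part of what the source reports. "The series", "measured", "known", "first", "only" and "open" are said of these compounds alone.

Three compounds on a shared core were measured in an ADME assay (Homo sapiens) for cytotoxicity; a lower number here means that less compound is tolerated, a higher number that more compound is tolerated. Compound 1 `CC(=O)N1CCC(C(=O)N(CCCN2CCN(Cc3ccccc3)CC2)c2ccc(C)c(Cl)c2)CC1` gives 101000 nM. Compound 2 `CC(=O)N1CCC(C(=O)N(CCCN2CCN(Cc3ccc(Cl)cc3)CC2)c2ccc(C)c(Cl)c2)CC1` gives 37600 nM, a change of a 2.7-fold lower number from compound 1 to compound 2 (0.43 log units; beyond the scatter). Compound 3 `CC(=O)N1CCC(C(=O)N(CCCN2CCN(Cc3ccc(C#N)cc3)CC2)c2ccc(C)c(Cl)c2)CC1` is reported only as a limit, > 100000 nM. The measured step reads an at least 2.6-fold higher number from compound 2 to compound 3 (0.42 log units; beyond the scatter), and the step from compound 1 to compound 3 cannot be sized (the limit of > 100000 nM in this assay, at which 1 of the 3 values shown sits). Compound 4 `CC(=O)N1CCC(C(=O)N(CCCN2CCN(Cc3cccnc3)CC2)c2ccc(C)c(Cl)c2)CC1` differs from compound 3 by pyridin-3-yl in place of 4-cyanophenyl on a saturated chain carbon bound to an amine nitrogen in a ring. Among the measured compounds shown here, no measured step exchanges the whole ring, and the steps seen concern substituents on it, all staying near the top of the measured range. The estimate for compound 4 is therefore 100000 nM, within 40000 nM to 250000 nM. The expected step is a number no higher from compound 3 to compound 4 (the limit leaves the size open), none beyond the scatter.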

Compound 4, half-maximal cytotoxic concentration: > 56700 nM
Compound 4: a limit, no number (the forecaster's own chance of this, stated with the estimate: 55%); the middle value lies beyond the limit too.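

Among the compounds shown here, compound 4 is the first here to carry a hetero atom in the aromatic ring on the saturated chain carbon bound to an amine nitrogen in a ring, and in this assay compound 4 too is reported only as a limit: the limit of > 56700 nM in this assay, at which 1 of the 4 values shown sits. Set against 4-chlorophenyl, pyridin-3-yl gives an at least 1.5-fold higher number from compound 2 to compound 4 (0.17 log units; that floor lies within the scatter), so this floor alone does not set the two groups apart. The steps to compound 4 from compound 1 and compound 3 cannot be read. From the compounds shown here alone, whether a pyridin-4-yl or 4-methoxyphenyl group at this place would give a number rather than a limit stays open.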